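From methyl to fluoro on an aromatic ring

The source may hold more compounds than are shown below. What is called first, only, known or untested is meant among the compounds shown, and "the series" means these compounds.

In a functional assay on the whole organism for antagonist activity, with Mus musculus as the target, in the maximal electroshock model (a higher number here means that more compound is needed for the effect, a lower number that less compound is needed), compound 1 `CC(=O)NC1=NC(c2ccccc2)CN1` gives 54 mg/kg and compound 2 `CCC(=O)NC1=NC(c2ccccc2)CN1` gives 75 mg/kg as its result. Compound 3 `COC(=O)NC1=NC(c2cccc(C)c2)CN1` gives 100 mg/kg and so stands within the scatter of both. For the measured compounds named here, in compound 4 `COC(=O)NC1=NC(c2cccc(F)c2)CN1` fluoro takes the place of methyl on an aromatic carbon fluoro in place of methyl on an aromatic carbon as the only difference from compound 3. Going by the values given here, no measured pair shows this swap. Among the compounds with values here, the one measured step is a 1.4-fold higher number from compound 1 to compound 2 (0.14 log units; within the scatter) for methyl in place of hydrogen on a saturated chain carbon, a different change that stays within the scatter. The estimated step is a 1.3-fold lower number from compound 3 to compound 4 (0.10 log units; within the scatter) and so no real shift is expected. In this assay compound 4 is expected to give 80 mg/kg with a range from 40 mg/kg to 160 mg/kg as estimated.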

Compound 4, dose for half-maximal effect: 70 mg/kg
Beside the measured number, compound 4's estimate is 1.1-fold (0.06 log units) above it, within the range that was stated.
By their numbers in this assay, from the lowest: compounds 1, 4, 2 and 3 (each within the scatter of the next).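

In this assay, for the compounds shown here, this is the first measured change on the aromatic ring, and it gives a 1.4-fold lower number from compound 3 to compound 4 (0.15 log units; within the scatter). At this carbon, meta to a large group, fluoro and methyl therefore cannot be told apart by this read-out, even though the two groups are different atoms. No available measurement explains the step. From the compounds shown here alone, whether an amine or a methoxy group on the same aromatic carbon would move the number beyond the scatter stays open. So does whether fluoro in place of methyl would act the same way with the acyl groups of compound 1 or compound 2.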